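Aryl Variation Without Shift in Atrial Agonist Response

A few compounds are considered here, and "the series" means these few. Any claim that something is new, unique, unknown or untested is made for them only; others in the source may bear on it.

Three compounds sharing one core have been examined in a functional assay on cardiac atrium for agonist activity at histamine H2 receptor (Cavia porcellus); on this read-out lower numbers stand for smaller maximal responses and higher numbers for larger maximal responses. Compound 1 `N=C(NCCCc1c[nH]cn1)NCCC(c1ccccc1)c1ccccn1` gives 1. Compound 2 `N=C(NCCCc1c[nH]cn1)NCCC(c1ccc(Cl)cc1)c1ccccn1` gives 1, and compound 3 `N=C(NCCCc1c[nH]cn1)NCCC(c1cccc(C(F)(F)F)c1)c1ccccn1` gives 1. On these numbers compound 3 stands level with compound 1 and compound 2: the step of no change at the digits printed from compound 1 to compound 3 (within the scatter) and the step of no change at the digits printed from compound 2 to compound 3 (within the scatter) both lie within the scatter, as does no change at the digits printed from compound 1 to compound 2 (within the scatter).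

Compound 4 `N=C(NCCCc1c[nH]cn1)NCCC(c1ccc(Cl)c(Cl)c1)c1ccccn1` differs from compound 3 in one place: 3,4-dichlorophenyl in place of 3-(trifluoromethyl)phenyl on a saturated chain carbon bound to an aromatic carbon and a saturated chain carbon. Going by the values given here, the steps that bear on this change are the three already seen, each an exchange of the aryl group on the same saturated chain carbon, and none of them moved the response beyond the scatter. A step of no size beyond the scatter is therefore expected in this assay for no change at the digits printed from compound 3 to compound 4 (within the scatter). Compound 4 is accordingly estimated to give 1, with an expected range from 0.9 to 1.05.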

Compound 4, intrinsic activity: the largest response reached, as a fraction of the reference agonist's: 1
For compound 4 middle estimate and measured number coincide at the digits printed; the range from low to high includes it.
By their numbers in this assay, from the lowest: compounds 1, 2, 3 and 4 (each within the scatter of the next).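

On the saturated chain carbon bound to an aromatic carbon and a saturated chain carbon, the aryl group now carries two chloro substituents, and replacing 3-(trifluoromethyl)phenyl with 3,4-dichlorophenyl gives no change at the digits printed from compound 3 to compound 4 (within the scatter) as the result. Chloro in place of hydrogen on the 4-chlorophenyl group gives no change at the digits printed from compound 2 to compound 4 (within the scatter) as its result, and the full exchange of phenyl for 3,4-dichlorophenyl gives no change at the digits printed from compound 1 to compound 4 (within the scatter) as its result. In this assay the maximal response therefore stays level across all four aryl groups shown, and no compound here goes against this.

The data shown offer no explanation for this sameness. Still open, as far as these compounds go, is what an amine, a carboxylic acid or a longer chain in place of the aryl group on this carbon would give.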